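This account rests on a few compounds, and the source may have more. Where it says the series, first, only, none or still open, it means among the compounds named here.

Measured in an ADME assay on MT4 cells (Homo sapiens) for inhibition, read by MTT assay, with a stated time of 5 days; on this read-out lower numbers stand for higher toxicity in this test and higher numbers for lower toxicity in this test:
- compound 1 `Cc1cccc(C)c1Oc1cc(Nc2ccc(C#N)cc2)ncc1[N+](=O)[O-]`: 126000 nM
- compound 2 `Cc1cc(C)c(Oc2cc(Nc3ccc(C#N)cc3)ncc2[N+](=O)[O-])c(C)c1`: 69900 nM
- compound 3 `N#Cc1ccc(Nc2cc(Oc3c(Cl)cc([N+](=O)[O-])cc3Cl)c([N+](=O)[O-])cn2)cc1`: 26500 nM

Compound 1 sits at the high end of these numbers, within the scatter of compound 2 and beyond the scatter from compound 3. The step to compound 4 `N#Cc1ccc(Nc2cc(Oc3c(Br)cc(Br)cc3Br)c([N+](=O)[O-])cn2)cc1` is 2,4,6-tribromophenyl in place of 2,6-dimethylphenyl on an oxygen on an aromatic ring. Going by the values given here, the only measured step, a 1.8-fold lower number from compound 1 to compound 2 (0.26 log units; within the scatter), adds one methyl and stays within the scatter, so it says little about bromine. The nearest guide is compound 3, which carries chlorine in the group on that oxygen and gives 26500 nM. A lower number, beyond the scatter, is therefore expected in this assay. The expected change is a 4.2-fold lower number from compound 1 to compound 4 (0.62 log units; beyond the scatter). Compound 4 is estimated at 30000 nM, with an expected range from 9000 nM to 90000 nM.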

Compound 4, half-maximal cytotoxic concentration: 7490 nM
Compound 4: the middle estimate sits 4.0-fold (0.60 log units) above what was measured, outside the stated range (below it).
By their numbers in this assay, from the lowest: compound 4; then compound 3; then compounds 2 and 1 (each within the scatter of the next).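

Two steps in this assay show that the read-out responds strongly to the group on this oxygen: a 17-fold lower number from compound 1 to compound 4 (1.23 log units; beyond the scatter) and a 9.3-fold lower number from compound 2 to compound 4 (0.97 log units; beyond the scatter) both lie beyond the scatter, unlike the earlier methyl step. The second of these keeps the substitution places and the ring type and exchanges only methyl groups for bromine atoms, so the shift goes with that exchange. Nothing at hand explains the shift.

The compounds shown leave open how much of the shift a single bromine would give, and whether fluorine atoms or an amine on this ring would shift the number in the same direction.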